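This account rests on a few compounds, and the source may have more. Where it says the series, first, only, none or still open, it means among the compounds named here.

Three compounds have been measured in a functional assay on RAW264.7 cells (Rattus norvegicus) for inhibition, with RAW264.7 (Mus musculus) as the target, read by Griess assay, with stated times of 2 h and 16 h; on this read-out higher numbers stand for weaker inhibition and lower numbers for stronger inhibition:

Compound 1 `COc1ccc2c(c1O)O[C@@H](c1cccc(O)c1O)[C@H](O)C2=O`: 88500 nM
Compound 2 `COc1ccc2c(c1)O[C@@H](c1cccc(O)c1O)[C@H](O)C2=O`: 30300 nM
Compound 3 `O=C1c2ccccc2O[C@H](c2cccc(O)c2O)[C@H]1O`: > 100000 nM, which is a limit of the assay and not a number

Among the measured compounds shown here, the one step that can be counted lies between compound 2 and compound 1. The change is hydroxy in place of hydrogen on an aromatic carbon, and it gave a 2.9-fold higher number from compound 2 to compound 1 (0.47 log units; beyond the scatter). For compound 3 only the limit is known, and the value sits at the limit of > 100000 nM in this assay, at which 1 of the 3 values shown sits. The difference between the core of compound 3 and the core of compound 2 is not broken down here.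

The unmeasured compound 4 `O=C1c2cc(O)ccc2O[C@H](c2cccc(O)c2O)[C@H]1O` carries the change hydroxy in place of hydrogen on an aromatic carbon relative to compound 3. For the measured compounds named here, this is the same kind of change as the one from compound 2 to compound 1, though not the same: in compound 1 the entering hydroxy sits ortho to a fused ring, ortho to a methoxy group and meta to a fused ring, while in compound 4 it sits meta to a fused ring and para to a fused ring, with no methoxy group present.

On the earlier step, which weakened inhibition, the expectation for compound 4 is a step that the limit leaves unreadable from compound 3 to compound 4, so that compound 4 is expected to give no stronger inhibition than compound 3 and most likely again only a limit. The estimate for compound 4 in this assay is 160000 nM, with a range from 60000 nM to 500000 nM.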

Compound 4, half-maximal inhibitory concentration: > 100000 nM
Compound 4: no number, only a limit (the forecaster's own chance of this, stated with the estimate: 80%); the middle value does not contradict the limit.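

In this assay compound 4 gives > 100000 nM, which is a limit of the assay and not a number. Compound 3 also gives only a limit, so no step can be read between compound 3 and compound 4: the limit of > 100000 nM in this assay, at which 2 of the 4 values shown sit. The compounds shown leave open whether hydroxy in place of hydrogen at this place changes inhibition on the core of compound 3, and in which direction.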